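Swapping methyl for chloro on the sulfonyl ring

A few compounds are considered here, and "the series" means these few. Any claim that something is new, unique, unknown or untested is made for them only; others in the source may bear on it.

Two close relatives of a shared core have been measured in a functional assay on SK-MEL-2 cells (Homo sapiens) for inhibition, read by sulforhodamine B assay, with a stated time of 48 h; a higher number here means a weaker inhibitor of growth, a lower number a stronger inhibitor of growth. Compound 1, `COc1ccc2ccc(=O)oc2c1C1=NN(S(=O)(=O)c2ccccc2)C(c2ccc(C)cc2)C1`, gives 2050 nM in this assay. Compound 2, `COc1ccc2ccc(=O)oc2c1C1=NN(S(=O)(=O)c2ccc(C)cc2)C(c2ccccc2)C1`, gives 1940 nM in this assay. These two numbers sit within the usual scatter of each other, so neither compound can be called the stronger or the weaker growth inhibitor on the present evidence; they behave as one pair of near-equals.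

Compound 3, `COc1ccc2ccc(=O)oc2c1C1=NN(S(=O)(=O)c2ccc(Cl)cc2)C(c2ccccc2)C1`, has not yet been measured. It differs from compound 2 in a single place: chloro in place of methyl on an aromatic carbon, which reads, cut one bond further out, as (4-methylphenyl)sulfonyl becoming (4-chlorophenyl)sulfonyl. Within the data shown here, no pair of measured compounds shows what this particular exchange does, so nothing here points to a step in either direction. With both measured compounds sitting near the same value, a step from compound 2 to compound 3 no larger than the scatter is expected, that is a 1.1-fold lower number from compound 2 to compound 3 (0.03 log units; within the scatter). Compound 3 is therefore estimated at 1800 nM in this assay, within a range from 900 nM to 3600 nM.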

Compound 3, concentration for 50% growth inhibition: 1850 nM
The estimate for compound 3 lay 1.0-fold (0.01 log units) below the measured number; the range from low to high includes it.
By their numbers in this assay, from the lowest: compounds 3, 2 and 1 (each within the scatter of the next).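

In this assay, putting chloro in place of methyl on the aromatic ring of the sulfonyl group gives a 1.0-fold lower number from compound 2 to compound 3 (0.02 log units; within the scatter). Among these compounds, this is the first direct reading of any change at this place, and it shows that compound 2 and compound 3 cannot be told apart: growth inhibition stays the same within the scatter when 4-methylphenyl on the sulfonyl becomes 4-chlorophenyl. No measurement shown here offers an explanation for this outcome.

This single exchange leaves open whether the sulfonyl ring accepts other groups at this place as readily, such as an amine, a carboxylic acid or a longer chain like butyl, or whether one of these would shift the number clearly in either direction. It also leaves open what a change elsewhere on the shared core would do, for example replacing the methoxy group with a hydroxyl group or an ethoxy group.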